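The source may hold more compounds than are shown below. What is called first, only, known or untested is meant among the compounds shown, and "the series" means these compounds.

Compound 2 `Cc1ccc(Nc2nc(C)c(C(=O)/C=C/c3ccccc3)s2)cc1` carries a 4-methylphenyl on a nitrogen of the shared core. In a functional assay on PC-3 cells (Homo sapiens) for cytotoxicity, read by MTT assay (a lower number here means a stronger inhibitor, a higher number a weaker inhibitor), compound 2 gives > 25000 nM, which is a limit of the assay rather than a measured number. Two relatives have been tested alongside it. Compound 1 `Cc1ccccc1Nc1nc(C)c(C(=O)/C=C/c2ccccc2Cl)s1` gives > 25000 nM in this assay, again a limit. Compound 3 `Cc1ccc(Nc2nc(C)c(C(=O)/C=C/c3ccccc3Cl)s2)cc1` gives > 25000 nM in this assay, also a limit. Because (the limit of > 25000 nM in this assay, at which 3 of the 3 values shown sit), every value seen so far stands at the same limit, and neither a step that the two limits leave unreadable from compound 1 to compound 3 nor a step that the two limits leave unreadable from compound 2 to compound 3 can be read as a step of any size.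

Compound 4 `Cc1nc(Nc2ccc(Cl)c(Cl)c2)sc1C(=O)/C=C/c1ccccc1` is the compound still to be measured. The change from compound 2 is 3,4-dichlorophenyl in place of 4-methylphenyl on a nitrogen on an aromatic ring. For the measured compounds named here, no measured step involves a 3,4-dichlorophenyl, and the two steps that are known are unreadable, so there is no footing for a shift in either direction in this assay beyond the scatter. The expectation for compound 4 is therefore that it also sits at or near the limit, with an estimated 30000 nM (range 8000 nM to 120000 nM). The expected step is accordingly a step that the limit leaves unreadable from compound 2 to compound 4, which amounts to essentially none.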

Compound 4, half-maximal inhibitory concentration: 7990 nM
Beside the measured number, compound 4's estimate is 3.8-fold (0.57 log units) above it; measured number below the stated range.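

For the compounds shown here, this is the first result in this assay that is a number rather than a limit, and it shows that the group on the nitrogen of the shared core can change the reading: 3,4-dichlorophenyl in place of 4-methylphenyl gives an at least 3.1-fold lower number from compound 2 to compound 4 (0.49 log units; beyond the scatter). From the compounds shown here alone, compound 2 gives > 25000 nM, which is a limit, so the true size of this step remains unknown and the printed size is only a minimum. The earlier steps, among compounds 1, 2 and 3, cannot be read, and the change at this nitrogen is the only one shown with a readable effect, as the other compounds offer no number to compare: the limit of > 25000 nM in this assay, at which 3 of the 4 values shown sit.

Going by these compounds, it remains open whether a single chlorine, as in a 4-chlorophenyl or a 3-chlorophenyl, would do the same as the two together, or whether other groups on that ring, such as a methoxy or an amine, would lower the number further. Also open, on these data alone, is whether a chloro on the other aromatic ring, whose step cannot be read from compound 2 to compound 3, would have any readable effect alongside 3,4-dichlorophenyl.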